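Swapping 1H-1,2,4-triazol-1-yl for pyrazin-2-yl on the shared core

This account rests on a few compounds, and the source may have more. Where it says the series, first, only, none or still open, it means among the compounds named here.

Within the data shown here, in a functional assay (trachea) with Cavia porcellus as the target (on this read-out lower numbers stand for stronger inhibition and higher numbers for weaker inhibition), compound 2 `CCn1nc(-n2cncn2)c2ccccc2c1=O` gives 15800 nM, the higher of the two numbers so far, while compound 1 `CCn1nc(-c2cccnc2)c2ccccc2c1=O` gives 1320 nM. Compound 3 `CCn1nc(-c2cnccn2)c2ccccc2c1=O` carries pyrazin-2-yl in place of 1H-1,2,4-triazol-1-yl on an aromatic carbon. Among the measured compounds shown here, the only measured step that bears on this is the large 12-fold higher number from compound 1 to compound 2 (1.08 log units; beyond the scatter), which swapped pyridin-3-yl for 1H-1,2,4-triazol-1-yl. Pyrazin-2-yl is closer in kind to pyridin-3-yl, so most of that step is expected to be recovered in this assay. The expected change is a 4.5-fold lower number from compound 2 to compound 3 (0.65 log units; beyond the scatter). For compound 3 the estimated value is 3500 nM, within a range of 900 nM to 13000 nM.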

Compound 3, half-maximal inhibitory concentration: 11000 nM
The estimate for compound 3 lay 3.1-fold (0.50 log units) below the measured number; the measured number falls inside the stated range.
By their numbers in this assay, from the lowest: compound 1; then compounds 3 and 2 (each within the scatter of the next).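

In this assay, replacing 1H-1,2,4-triazol-1-yl with pyrazin-2-yl gives a 1.4-fold lower number from compound 2 to compound 3 (0.16 log units; within the scatter), so this exchange has no readable effect at this position. A six-membered aromatic ring in this place does not by itself match compound 1, as an 8.3-fold higher number from compound 1 to compound 3 (0.92 log units; beyond the scatter) shows for pyrazin-2-yl in place of pyridin-3-yl. Nothing measured here explains the difference between these two rings.

On these data alone, it remains open whether the lower number of compound 1 depends on where the ring nitrogen lies, as a pyridin-4-yl group would test. A plain phenyl group would show whether any ring nitrogen is needed at all.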